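The source may report more compounds than this note shows. Statements on the series, on what has been measured and on what is new or still open speak of the compounds shown alone.

- Compound 1 `COc1cccc(/C=C2\CCC/C(=C\c3ccccc3Cl)C2=O)c1OC`: 11700 nM
- Compound 2 `COc1cccc(/C=C2\CCC/C(=C\c3ccc(Cl)c(Cl)c3)C2=O)c1OC`: 10800 nM

Going by the values given here, in a functional assay on HT-1080 cells (Homo sapiens) for cytotoxicity, read by MTT assay, with a stated time of 72 h (a higher number here means a weaker inhibitor, a lower number a stronger inhibitor), compound 2 gives 10800 nM, level with the only other measured compound, the step being a 1.1-fold lower number from compound 1 to compound 2 (0.03 log units; within the scatter). Compound 3 `COc1cccc(/C=C2\CCC/C(=C\c3ccc(O)c(O)c3)C2=O)c1OC` differs from compound 2 in one group: 3,4-dihydroxyphenyl in place of 3,4-dichlorophenyl on a double-bonded chain carbon bound to a double-bonded ring carbon. This places 3,4-dihydroxyphenyl in place of 3,4-dichlorophenyl on a double-bonded chain carbon bound to a double-bonded ring carbon. Among the compounds with values here, only the one measured step bears on this place, and it exchanged one chlorinated phenyl for another. Within the data shown here, no compound carrying hydroxyl groups has been measured, so the data give weak guidance. A modest move towards a lower number in this assay is expected, though a result within the scatter would be equally unsurprising. The expected change is a 1.8-fold lower number from compound 2 to compound 3 (0.26 log units; within the scatter). Compound 3 is estimated at 6000 nM, with an expected range of 1800 nM to 16000 nM.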

Compound 3, half-maximal inhibitory concentration: 4700 nM
The estimate for compound 3 lay 1.3-fold (0.11 log units) above the measured number, and the stated range covers the measured number.
By their numbers in this assay, from the lowest: compound 3; then compounds 2 and 1 (each within the scatter of the next).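

In this assay the place on a double-bonded chain carbon bound to a double-bonded ring carbon now responds beyond the scatter: 3,4-dihydroxyphenyl in place of 3,4-dichlorophenyl gives a 2.3-fold lower number from compound 2 to compound 3 (0.36 log units; beyond the scatter) and 3,4-dihydroxyphenyl in place of 2-chlorophenyl gives a 2.5-fold lower number from compound 1 to compound 3 (0.40 log units; beyond the scatter) at the same place. The earlier exchange of one chlorinated phenyl for another had stayed within the scatter, so this place is shown for the first time to be able to change the number, though both steps are only modest. Nothing at hand accounts for the shift.

Whether both hydroxyl groups are needed remains open, since a phenyl carrying a single hydroxyl does not appear among these compounds. On these data alone, how a 3,4-dimethoxyphenyl or an aminophenyl group would read at this place also remains open.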